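Amine variation on the ring nitrogen of the shared core

The compounds below may be only part of what the source reports. "The series", "measured", "known", "first", "only" and "open" are said of these compounds alone.

Measured so far, in an assay on HEK293 cells for displacement of a labelled ligand from B1 bradykinin receptor (Homo sapiens), read by scintillation counting; a higher number here means a weaker inhibitor, a lower number a stronger inhibitor:
compound 1 `COc1cc(C)c(S(=O)(=O)N(C)CCOCC(=O)N2CCN(C3CCN(C4CC4)CC3)CC2)c(C)c1` gives 0.8 nM
compound 2 `CCN(CC)CCN1CCN(C(=O)COCCN(C)S(=O)(=O)c2c(C)cc(OC)cc2C)CC1` gives 10 nM
compound 3 `COc1cc(C)c(S(=O)(=O)N(C)CCOCC(=O)N2CCN(CCCN(C)C)CC2)c(C)c1` gives 5.8 nM

Compound 3 stands second highest of the three numbers. Its nearest neighbour is compound 2, with a 1.7-fold lower number from compound 2 to compound 3 (0.24 log units; within the scatter), a gap that sits within the scatter, so no order between compound 2 and compound 3 is claimed. Its furthest is compound 1, with a 7.3-fold higher number from compound 1 to compound 3 (0.86 log units; beyond the scatter); compound 1 is the strongest inhibitor of the three, its steps to both others lying beyond the scatter.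

The next compound, compound 4 `COc1cc(C)c(S(=O)(=O)N(C)CCOCC(=O)N2CCN([C@H]3CN4CCC3CC4)CC2)c(C)c1`, differs from compound 3 in one place: a group of 8 heavy atoms (7 carbon, 1 nitrogen; 2 six-membered non-aromatic rings with 1 hetero atom each) in place of a group of 6 heavy atoms (5 carbon, 1 nitrogen; no ring), on an amine nitrogen in a ring

Among the compounds with values here, two measured steps bear on this change. Both a 7.3-fold higher number from compound 1 to compound 3 (0.86 log units; beyond the scatter) and a 13-fold higher number from compound 1 to compound 2 (1.10 log units; beyond the scatter) replace the 1-cyclopropylpiperidin-4-yl of compound 1, whose amine nitrogen sits in a ring, by an open-chain amine, and both raise the number beyond the scatter. The group entering in compound 4 returns the amine nitrogen to a ring, so a step back toward compound 1 is expected, of a size between those two steps. The estimate for compound 4 is a 3.9-fold lower number from compound 3 to compound 4 (0.59 log units; beyond the scatter), giving an expected 1.5 nM with a range from 0.5 nM to 5 nM.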

Compound 4, inhibition constant: 34 nM
Beside the measured number, compound 4's estimate is 23-fold (1.36 log units) below it; measured number above the stated range.
By their numbers in this assay, from the lowest: compound 1; then compounds 3 and 2 (each within the scatter of the next); then compound 4.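

Putting the amine nitrogen back into a ring does not by itself lower the number at this position: in this assay, the entering group with its 2 six-membered non-aromatic rings gives a 5.9-fold higher number from compound 3 to compound 4 (0.77 log units; beyond the scatter) and a 3.4-fold higher number from compound 2 to compound 4 (0.53 log units; beyond the scatter), so the open-chain amines both do better here. Compound 4 also lies far from compound 1, which likewise carries its amine nitrogen in a ring, with a 43-fold higher number from compound 1 to compound 4 (1.63 log units; beyond the scatter), leaving compound 4 the weakest inhibitor of the four, so ring versus open chain does not order this series: compound 1 fits a preference for the ring and compound 4 goes against it. No supporting data are available to account for the difference between these two ring-bearing groups.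

The compounds shown leave open whether the single defined stereocentre of the entering group matters, a question the mirror-image form of that group would address. They also leave open whether the low number of compound 1 depends on its cyclopropyl group, which a 1-methylpiperidin-4-yl or an unsubstituted piperidin-4-yl on the same ring nitrogen would test.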